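A Triazolylmethyl Replacement for the Carboxybenzyl Group

This account rests on a few compounds, and the source may have more. Where it says the series, first, only, none or still open, it means among the compounds named here.

compound 1 `CCC(CC)N(CCN(C)C(=O)CCC(=O)O)Cc1cccc(C(=O)Nc2sc3c(c2C(=O)c2cnn(-c4ccc(Cl)cc4)c2)CCC(C)(C)C3)c1` — 36 nM
compound 2 `CCC(CC)N(CCN(C)C(=O)CCC(=O)O)Cc1cccc(C(=O)Nc2sc3c(c2C(=O)c2cnn(-c4cccc(C(F)(F)F)c4)c2)CCC(C)(C)C3)c1` — 46 nM
compound 3 `CCC(CC)N(CCN(C)C(=O)CCC(=O)O)Cc1cccc(C(=O)Nc2sc3c(c2C(=O)c2cnn(Cc4ccc(C(=O)O)cc4)c2)CCC(C)(C)C3)c1` — > 1000 nM

In an assay on isolated protein for inhibition of sodium-dependent phosphate transport protein 2B (Homo sapiens) (a higher number here means a weaker inhibitor, a lower number a stronger inhibitor), compound 1 gives 36 nM and compound 2 gives 46 nM; the step of a 1.3-fold higher number from compound 1 to compound 2 (0.11 log units; within the scatter) stays within the scatter. For compound 3 the assay returns only a limit, > 1000 nM. On the numbers shown, compound 3 stands at the weak end of the three, since the steps of an at least 27-fold higher number from compound 1 to compound 3 (1.44 log units; beyond the scatter) and an at least 21-fold higher number from compound 2 to compound 3 (1.33 log units; beyond the scatter) are both large and beyond the scatter (the limit of > 1000 nM in this assay, at which 1 of the 3 values shown sits).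

Compound 4 `CCC(CC)N(CCN(C)C(=O)CCC(=O)O)Cc1cccc(C(=O)Nc2sc3c(c2C(=O)c2cnn(Cc4nnc[nH]4)c2)CCC(C)(C)C3)c1` has not yet been measured. It differs from compound 3 by 4H-1,2,4-triazol-3-yl in place of 4-carboxyphenyl on a saturated chain carbon bound to an aromatic nitrogen. Within the data shown here, no measured step covers this change directly; the two large steps that lead to compound 3 both concern exchanging an aryl group directly on the aromatic nitrogen for a 4-carboxybenzyl group, and compound 4 keeps the methylene link to the aromatic nitrogen. Compound 4 is therefore expected to remain weak, with the step that the limit leaves unreadable from compound 3 to compound 4 estimated to be small. The estimate for compound 4 in this assay is 3000 nM, with a range from 500 nM to 20000 nM, and a considerable chance that only a limit is reported again.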

Compound 4, half-maximal inhibitory concentration: > 1000 nM
Compound 4: no number, only a limit (the forecaster's own chance of this, stated with the estimate: 60%); the middle value lies beyond the limit too.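

In this assay compound 4 gives only a limit, > 1000 nM. It lies far from the compounds with an aryl group directly on the aromatic nitrogen, with an at least 27-fold higher number from compound 1 to compound 4 (1.44 log units; beyond the scatter) and an at least 21-fold higher number from compound 2 to compound 4 (1.33 log units; beyond the scatter), so the weak result seen with 4-carboxybenzyl does not depend on the 4-carboxyphenyl group and also appears with (4H-1,2,4-triazol-3-yl)methyl. The step from compound 3 to compound 4 cannot be read: the limit of > 1000 nM in this assay, at which 2 of the 4 values shown sit.

From the compounds shown here alone, how far beyond the limit compound 3 and compound 4 lie stays open, so the two groups cannot be ranked against each other. Also open, going by these compounds, is whether the chain carbon or the group it carries matters more, a question that a plain benzyl group, or a 4-carboxyphenyl directly on the aromatic nitrogen, would address.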